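This account rests on a few compounds, and the source may have more. Where it says the series, first, only, none or still open, it means among the compounds named here.

Measured compounds in the series:

Compound 1, `CC(C)N(Cc1cccc(OCCCCCC(=O)O)c1)C(=O)c1ccc(-c2ccncc2)cc1`, reports in an ADME assay on HepG2 cells (Homo sapiens) for cytotoxicity, read by CellTiter-Glo and resazurin assay, with a stated time of 72 h (a lower number here means that less compound is needed, a higher number that more compound is needed for the effect), only a limit of > 26000 nM.
Compound 2, `CC(C)N(Cc1cccc(OCCCCCC(=O)O)c1)C(=O)c1ccc(-c2cccc(OCc3ccccc3)c2)cc1`, reports in this assay only a limit of > 26000 nM.
Compound 3, `CCOC(=O)CCCCCOc1cccc(CN(C(=O)c2ccc(-c3cccc(OCc4ccccc4)c3)cc2)C(C)C)c1`, reports in this assay only a limit of > 26000 nM.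

Among the compounds with values here, compound 3 therefore stands at the assay limit, and the two further values shown are limits as well, so no compound of the series has a readable number in this assay. Within the data shown here, the single step between measured compounds, a step that the two limits leave unreadable from compound 2 to compound 3, cannot be sized because the limit of > 26000 nM in this assay, at which 3 of the 3 values shown sit, caps both of its ends.

Compound 4 is `CCOC(=O)CCCCCOc1cccc(CN(C(=O)c2ccc(-c3cccc([N+](=O)[O-])c3)cc2)C(C)C)c1`. It differs from compound 3 as follows: nitro in place of benzyloxy on an aromatic carbon. Among the measured compounds shown here, no measured step bears on this change, since no pair of measured compounds exchanges benzyloxy for nitro. Compound 1, which lacks the benzyloxy group, also reports only the limit in this assay.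

With every value in the series sitting at the limit, the step that the limit leaves unreadable from compound 3 to compound 4 is expected to show nothing beyond the scatter, and compound 4 is expected to report a limit again. The estimate for compound 4 in this assay is 30000 nM, with a range from 15000 nM to 70000 nM.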

Compound 4, half-maximal effective concentration: > 26000 nM
Compound 4: a limit, no number; the forecaster's own chance of this, stated with the estimate: 85%; the middle value does not contradict the limit.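

Compound 3 and compound 4 both report only a limit in this assay, so nitro in place of benzyloxy gives no readable step, because both ends are capped: the limit of > 26000 nM in this assay, at which 4 of the 4 values shown sit.

The compounds shown leave open whether any member of the series reaches a readable half-maximal effective concentration in this assay.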